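From tert-butyl to methylsulfanyl on compound 1

The source may report more compounds than this note shows. Statements on the series, on what has been measured and on what is new or still open speak of the compounds shown alone.

Of the compounds shown here, three sharing one core have been measured in a physicochemical assay for solubility, at pH 7.4; a lower number here means a less soluble compound, a higher number a more soluble compound. Compound 1 (`Cc1cc(NC(=O)Nc2ccc(C(C)(C)C)cc2)c2ccccc2n1`) gives 6200 nM. Compound 2 (`Cc1cc(NC(=O)Nc2ccccc2OC(F)(F)F)c2ccccc2n1`) gives 4600 nM, which lies within the usual scatter of compound 1, so the two count as level at the top of this small set. Compound 3 (`Cc1cc(NC(=O)Nc2ccc(Cl)c(Cl)c2)c2ccccc2n1`) gives 300 nM, lower than both and well beyond the scatter.

Compound 4 (`CSc1ccc(NC(=O)Nc2cc(C)nc3ccccc23)cc1`) has not yet been measured. It carries methylsulfanyl in place of tert-butyl on an aromatic carbon, para to a large group (methylsulfanyl in place of tert-butyl on an aromatic carbon). Among the measured compounds shown here, no measured pair shows this change on its own, so the expectation is loose. Compound 3, at 300 nM, shows that a different group on the shared core can pull the number far down, while compound 2, at 4600 nM, shows that it need not. A moderate downward step in this assay, somewhat beyond the scatter, is therefore expected. The estimated step runs a 3.4-fold lower number from compound 1 to compound 4 (0.54 log units; beyond the scatter). For compound 4 the estimated value is 1800 nM, within an expected range of 400 nM to 6000 nM.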

Compound 4, solubility: 1300 nM
For compound 4 the middle estimate is 1.4-fold (0.14 log units) above the measured one; low and high end bracket the measured number.
By their numbers in this assay, from the lowest: compound 3; then compound 4; then compounds 2 and 1 (each within the scatter of the next).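

In this assay, among the compounds shown here, compounds 1 and 4 form the only pair here that differs in one place, and the step of a 4.8-fold lower number from compound 1 to compound 4 (0.68 log units; beyond the scatter) shows that the number depends on which group sits on this aromatic carbon. Methylsulfanyl has fewer heavy atoms than tert-butyl and adds a hydrogen-bond acceptor, so in this one pair, a smaller group with an acceptor goes with a lower number, not a higher one. Nothing available here accounts for the drop.

A single pair cannot separate the part played by the sulfur from that of the change in size or shape. It also leaves open how a methoxy group, an amine or a carboxylic acid in the same place would compare with tert-butyl.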